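Dimethylamino to diethylamino in the series

The source may report more compounds than this note shows. Statements on the series, on what has been measured and on what is new or still open speak of the compounds shown alone.

Of the compounds shown here, two have numbers so far. In an ADME assay on MT4 cells (Homo sapiens) for cytotoxicity, read by spectrophotometry, with a stated time of 5 days (on this read-out lower numbers stand for higher toxicity in this test and higher numbers for lower toxicity in this test), compound 1 `CONC(=S)N/N=C1\C(=O)N(CN(C)C)c2ccc(F)cc21` gives 560000 nM and compound 2 `CONC(=S)N/N=C1\C(=O)N(CN(C)C)c2ccc(C)cc21` gives 622000 nM. Going by the values given here, compound 2 therefore stands level with compound 1, its only neighbour on these numbers, with a 1.1-fold higher number from compound 1 to compound 2 (0.05 log units; within the scatter). That single measured step is methyl in place of fluoro on an aromatic carbon.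

The next compound is compound 3 `CCN(CC)CN1C(=O)/C(=N\NC(=S)NOC)c2cc(C)ccc21`, which keeps the methyl and the shared core of compound 2 and changes the side chain: diethylamino in place of dimethylamino on a saturated chain carbon bound to an amide-type nitrogen in a ring. The same difference reads as (dimethylamino)methyl to (diethylamino)methyl. Among the compounds with values here, the measured step lies elsewhere on the structure, so no measurement yet tests a change at this place, and any expectation here is weakly founded. Starting from compound 2 at 622000 nM, no step beyond the scatter is expected in this assay, and the range is kept wide. The expected step is a 1.1-fold lower number from compound 2 to compound 3 (0.05 log units; within the scatter). For compound 3 the estimated value is 560000 nM, with an expected range of 280000 nM to 1000000 nM.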

Compound 3, half-maximal cytotoxic concentration: 573000 nM
For compound 3 the middle estimate is 1.0-fold (0.01 log units) below the measured one; the measured number falls inside the stated range.
By their numbers in this assay, from the lowest: compounds 1, 3 and 2 (each within the scatter of the next).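

In this assay the side chain now has its first test, and diethylamino in place of dimethylamino on a saturated chain carbon bound to an amide-type nitrogen in a ring gives a 1.1-fold lower number from compound 2 to compound 3 (0.04 log units; within the scatter) in the half-maximal cytotoxic concentration. The earlier step concerned only an aromatic carbon, whereas this one shows that, with methyl held on the shared core, going from 3 heavy atoms to 5 heavy atoms in the amino group does not separate compound 2 and compound 3 beyond the usual scatter of the read-out. No supporting data bear on why these two compounds stand level in this test.

Going by these compounds, the reading rests on a single pair and on one modest enlargement of the amino group, so it does not yet show how far this position tolerates change, and whether the same step would hold with fluoro in place of methyl on the aromatic carbon also stays open. On these data alone, how a longer chain on the amine nitrogen, or a carboxylic acid in place of diethylamino on that saturated chain carbon, would read in this assay remains open too.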